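The source may hold more compounds than are shown below. What is called first, only, known or untested is meant among the compounds shown, and "the series" means these compounds.

Working notes on the series. All three measured compounds share a core carrying two fluorophenyl-methylidene arms and an arylsulfonyl group; they are compound 1 `O=C1/C(=C/c2cccc(F)c2)CN(S(=O)(=O)c2ccc(C(F)(F)F)cc2)C/C1=C\c1cccc(F)c1`, compound 2 `O=C1/C(=C/c2ccc(F)cc2)CN(S(=O)(=O)c2ccccc2)C/C1=C\c1ccc(F)cc1` and compound 3 `O=C1/C(=C/c2ccc(F)cc2)CN(S(=O)(=O)c2ccc(O[N+](=O)[O-])cc2)C/C1=C\c1ccc(F)cc1`. In a functional assay on SMMC-7721 cells (Homo sapiens) for cytotoxicity, read by MTT assay, with a stated time of 24 h (on this read-out higher numbers stand for weaker inhibition and lower numbers for stronger inhibition), compound 1 gives 4200 nM, compound 2 gives 9100 nM and compound 3 gives 5000 nM. Compound 3 sits second of the three numbers, and neither its gap to compound 1 nor its gap to compound 2 exceeds the scatter. Among the measured compounds shown here, the one single-point step available, a 1.8-fold lower number from compound 2 to compound 3 (0.26 log units; within the scatter), concerns a change on the sulfonyl-bearing phenyl and is itself within the scatter.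

Compound 4 `N#Cc1ccc(S(=O)(=O)N2C/C(=C\c3ccc(F)cc3)C(=O)/C(=C/c3ccc(F)cc3)C2)cc1` continues from compound 3 with cyano in place of nitrooxy on an aromatic carbon. For the measured compounds named here, the only step that bears on it is the same phenyl position being changed from compound 2 to compound 3, and that step was within the scatter; no measured step speaks for a shift beyond the scatter in this assay in either direction. The estimated step is therefore no change at the digits printed from compound 3 to compound 4 (within the scatter), and compound 4 is expected to give about 5000 nM, in the range 2500 nM to 10000 nM.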

Compound 4, half-maximal inhibitory concentration: 15000 nM
For compound 4 the middle estimate is 3.0-fold (0.48 log units) below the measured one; measured number outside the range, above it.
By their numbers in this assay, from the lowest: compounds 1, 3, 2 and 4 (each within the scatter of the next, the first and the last beyond it).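

In this assay, among the compounds shown here, this position now shows a step beyond the scatter for the first time: a 3.0-fold higher number from compound 3 to compound 4 (0.48 log units; beyond the scatter), on going from 4-(nitrooxy)phenyl to 4-cyanophenyl. Measured against hydrogen, neither group separates: a 1.8-fold lower number from compound 2 to compound 3 (0.26 log units; within the scatter) and a 1.6-fold higher number from compound 2 to compound 4 (0.22 log units; within the scatter) both stay within the scatter, so the gap appears only between nitrooxy and cyano, not between either group and hydrogen. Nothing shown here gives a cause for this gap.

From the compounds shown here alone, with only hydrogen, nitrooxy and cyano compared at this position, it remains open where an amine or a carboxylic acid there would fall relative to these values. Also open, going by these compounds, is whether the gap between nitrooxy and cyano recurs with the fluorophenyl arms of compound 1.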